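A few compounds are considered here, and "the series" means these few. Any claim that something is new, unique, unknown or untested is made for them only; others in the source may bear on it.

Measured compounds:
compound 1, `CCNC(=O)c1ccc(NC2CCCCC2)c(NCc2ccccc2)c1`, 21 nM 
compound 2, `CCNC(=O)c1ccc(NC2CCCCC2)c(NCc2ccncc2)c1`, 26 nM 
compound 3, `CCNS(=O)(=O)c1ccc(NC2CCCC2)c(NCc2ccccc2)c1`, 8.2 nM 

In a functional assay (IMR-32 cells, Homo sapiens) for inhibition, read by fluorescence, with stated times of 1 h and 13 h (a lower number here means a stronger inhibitor, a higher number a weaker inhibitor), compound 1 gives 21 nM. Compound 2 differs from compound 1 by a single change, (pyridin-4-yl in place of phenyl on a saturated chain carbon bound to a nitrogen on an aromatic ring), and in this assay compound 2 gives 26 nM; the step is a 1.2-fold higher number from compound 1 to compound 2 (0.09 log units; within the scatter), so the two values cannot be told apart. Compound 3 carries a different core, and the difference between the core of compound 1 and the core of compound 3 is not broken down here. In this assay compound 3 gives 8.2 nM, the lowest of the three numbers, with compound 1 and compound 2 both beyond the scatter above it.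

Compound 4, `CCNS(=O)(=O)c1ccc(NC2CCCC2)c(NCc2ccncc2)c1`, has not yet been measured. It stands to compound 3 as compound 2 stands to compound 1: the difference is pyridin-4-yl in place of phenyl on a saturated chain carbon bound to a nitrogen on an aromatic ring, and since the place is described in the same words for both pairs, this is the same change made a second time, now on the core of compound 3. Going by the values given here, the one measured instance of it, a 1.2-fold higher number from compound 1 to compound 2 (0.09 log units; within the scatter), lay within the scatter, so compound 4 is expected to sit close to compound 3, with an expected step of a 1.2-fold higher number from compound 3 to compound 4 (0.09 log units; within the scatter) resting on that earlier step. In this assay compound 4 is estimated at 10 nM, with a likely range from 5 nM to 20 nM.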

Compound 4, half-maximal inhibitory concentration: 36 nM
For compound 4 the middle estimate is 3.6-fold (0.56 log units) below the measured one; the measured number lies above the stated range.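

In this assay, replacing phenyl with pyridin-4-yl did not carry over unchanged from one core to the other, as the two steps show when set side by side: the same change on two cores in this assay, a 1.2-fold higher number (0.09 log units; within the scatter) from compound 1 to compound 2 and a 4.4-fold higher number (0.64 log units; beyond the scatter) from compound 3 to compound 4, 3.5-fold (0.55 log units) apart, beyond the scatter of two such steps On the core of compound 3 the change gives a 4.4-fold higher number from compound 3 to compound 4 (0.64 log units; beyond the scatter), whereas on the core of compound 1 it could not be told from the scatter, so in this series a step read on one of these cores is a poor guide to the same change on the other. Going by these compounds alone, this does not show which part of the cores is responsible, since the difference between them is not broken down and each core supplies only a single pair, nor does it show that any other group placed on this saturated chain carbon would behave in the same way.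

The compounds shown carry only phenyl and pyridin-4-yl at this place, so it remains open whether pyridin-3-yl, pyridin-2-yl or a phenyl bearing a methoxy group would also respond differently on the two cores. Also open, from the compounds shown here alone, is how the step would read on a core that takes over only one part of the difference between the core of compound 1 and the core of compound 3.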